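Enlarging the sulfonyl aryl group in a quinazoline series

The source may report more compounds than this note shows. Statements on the series, on what has been measured and on what is new or still open speak of the compounds shown alone.

Compound 1 `COc1cc2nc(N3CCN(S(=O)(=O)c4ccc(C)cc4)CC3)nc(N)c2cc1OC` carries a 4-methylphenyl group on its sulfonyl sulfur. In a functional assay on PC-3 cells (Homo sapiens) for inhibition (a lower number here means a stronger inhibitor, a higher number a weaker inhibitor), compound 1 gives 30000 nM, the second highest of three numbers measured here. Its closest neighbour is compound 3 `COc1cc2nc(N3CCN(S(=O)(=O)c4ccc5ccccc5c4)CC3)nc(N)c2cc1OC`, which in this assay gives 15000 nM; the step is a 2.0-fold lower number from compound 1 to compound 3 (0.30 log units; within the scatter). Compound 2 `COc1cc2nc(N3CCN(S(=O)(=O)c4ccc(N)cc4N)CC3)nc(N)c2cc1OC` has the highest number, giving 67000 nM in this assay, a step of a 2.2-fold higher number from compound 1 to compound 2 (0.35 log units; beyond the scatter), and from compound 2 to compound 3 the step is a 4.5-fold lower number from compound 2 to compound 3 (0.65 log units; beyond the scatter).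

Compound 4 `COc1cc2nc(N3CCN(S(=O)(=O)c4ccc(-c5ccc(C)cc5)cc4)CC3)nc(N)c2cc1OC` differs from compound 1 by one change: 4-methylphenyl in place of methyl on an aromatic carbon. For the measured compounds named here, the one measured step that resembles this is the one from compound 1 to compound 3, where a larger aromatic group replaced the 4-methylphenyl on the sulfonyl sulfur and the number moved by a 2.0-fold lower number from compound 1 to compound 3 (0.30 log units; within the scatter), within the scatter. Nothing measured here speaks for a large move in either direction, so in this assay compound 4 is expected to sit close to compound 1, with at most a small shift towards a lower number, a 1.7-fold lower number from compound 1 to compound 4 (0.22 log units; within the scatter). The estimate for compound 4 is therefore 18000 nM, in a range from 5000 nM to 65000 nM.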

Compound 4, half-maximal inhibitory concentration: 3400 nM
Compound 4: middle estimate off by 5.3-fold (0.72 log units), on the high side; the measured number lies below the stated range.
By their numbers in this assay, from the lowest: compound 4; then compounds 3 and 1 (each within the scatter of the next); then compound 2.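

Placing 4-methylphenyl in place of methyl on this aromatic carbon, para to a large group, gives an 8.8-fold lower number from compound 1 to compound 4 (0.95 log units; beyond the scatter) in this assay. This shows that the position accepts a much larger carbon-only aromatic group and that such a group can lower the number by more than the scatter, which the fused ring of compound 3 did not show, with its a 2.0-fold lower number from compound 1 to compound 3 (0.30 log units; within the scatter). Nothing here explains why the added ring has this effect, and no measurement of its properties is available to account for the step.

The compounds shown leave open whether the gain comes from the added ring alone or also depends on the methyl at its far end, a question that an unsubstituted phenyl ring in that place would address. They also leave open whether the outer ring tolerates an amine, a carboxylic acid or a longer chain in place of that methyl, and whether the number would fall further or rise back towards that of compound 1.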